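From a Piperidine to an Anilino Group on the Core

This account rests on a few compounds, and the source may have more. Where it says the series, first, only, none or still open, it means among the compounds named here.

Of the compounds shown here, two have so far been tested in a functional assay on HepG2 cells (Homo sapiens) for antiproliferative activity, read by CCK-8 assay, with a stated time of 72 h, tested at 2 uM; a lower number here means a weaker effect, a higher number a stronger effect of the compound at the concentration tested. Compound 1 `CCC(C)n1cnc2c(NCc3ccc(C(=O)Nc4ccccc4N)cc3)nc(Cl)nc21` gives 45% in this assay, whereas compound 2 `CC1CCN(c2nc(Cl)nc3c2ncn3Cc2ccc(/C=C/C(=O)Nc3ccccc3N)cc2)CC1` gives 8.73%, the lowest of the two numbers; its gap to compound 1 lies beyond the usual scatter of repeated measurements. Compound 3 `Nc1ccccc1NC(=O)/C=C/c1ccc(Cn2cnc3c(Nc4cccc(Cl)c4)nc(Cl)nc32)cc1` has not been measured yet. Compared with compound 2, it carries a single change on the shared core: (3-chlorophenyl)amino in place of 4-methylpiperidin-1-yl on an aromatic carbon. Compound 1 likewise carries an amino group rather than a piperidine on its core and gives 45%, which is the only hint available. On that basis the step is expected to raise the read-out, by a number 21.3 percentage points higher from compound 2 to compound 3 (beyond the scatter), a move expected to fall beyond the scatter. Compound 3 is therefore estimated to give 30% in this assay, within a range from 5% to 60%.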

Compound 3, a percentage reported as inhibition, at one concentration (the size of the read-out at that concentration, not a potency): 35.8%
The estimate for compound 3 lay 5.8 percentage points below the measured number, and the stated range covers the measured number.
By their numbers in this assay, from the lowest: compound 2; then compounds 3 and 1 (each within the scatter of the next).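

In this assay the change from 4-methylpiperidin-1-yl to (3-chlorophenyl)amino on this aromatic carbon gives a number 27.1 percentage points higher from compound 2 to compound 3 (beyond the scatter) with the rest of the structure unchanged, so what stands at this position alters the read-out. Among the compounds shown here, this is the first direct reading of this position, as compound 1 differs from compound 2 in more than one place. The change replaces a non-aromatic ring with an aromatic one, adds a chlorine and brings 1 hydrogen-bond donor where there were 0, and no measurement shown explains the rise or singles out one of these differences.

A plain phenylamino group would show what the chlorine adds to this step. A cyclohexylamino group would separate the contribution of the amino link from that of the aromatic ring.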